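One Substituent Swap, Repeated on a Second Core

A few compounds are considered here, and "the series" means these few. Any claim that something is new, unique, unknown or untested is made for them only; others in the source may bear on it.

Of the compounds shown here, three have been measured in a functional assay on a cell-free system (plasma, Homo sapiens), with a stated time of 3 min; a lower number here means a stronger inhibitor, a higher number a weaker inhibitor. Compound 1 `O=C(NCc1cc(Cl)ccc1-n1cnnn1)[C@@H]1[C@@H]2C[C@@H]2CN1C(=O)[C@H](O)Cc1ccccn1` gives 1700 nM in this assay. Compound 2 `O=C(NCc1cc(Cl)ccc1-n1cnnn1)[C@@H]1[C@@H]2C[C@@H]2CN1C(=O)[C@H](O)c1ccccc1` gives 700 nM in this assay. Compound 3 `O=C(NCc1cc(Cl)ccc1-n1cnnn1)[C@@H]1C[C@@H]2C[C@@H]2N1C(=O)[C@H](O)c1ccccc1` gives 620 nM in this assay. Compound 2 and compound 3 are built from the same atoms joined differently; the difference between their two cores is not broken down here, and their two values lie within the usual scatter of each other.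

Compound 1 and compound 2 share a core and differ in one place: (pyridin-2-yl)methyl in place of phenyl on a saturated chain carbon bound to a carbonyl carbon and an oxygen on a saturated carbon. This change produced a 2.4-fold higher number from compound 2 to compound 1 (0.39 log units; beyond the scatter) in this assay.

Compound 4 `O=C(NCc1cc(Cl)ccc1-n1cnnn1)[C@@H]1C[C@@H]2C[C@@H]2N1C(=O)[C@H](O)Cc1ccccn1` has not been measured. It stands to compound 3 as compound 1 stands to compound 2: (pyridin-2-yl)methyl in place of phenyl on a saturated chain carbon bound to a carbonyl carbon and an oxygen on a saturated carbon. The place of the change is described in the same words for both pairs, so this is the same change made on the core of compound 3 rather than the core of compound 2.

Among the compounds with values here, because the only measured instance of this change is a 2.4-fold higher number from compound 2 to compound 1 (0.39 log units; beyond the scatter), and because compound 3 starts from 620 nM, compound 4 is expected to show a step of about a 2.4-fold higher number from compound 3 to compound 4 (0.38 log units; beyond the scatter) in this assay. With one prior example to rest on, the estimate for compound 4 in this assay is 1500 nM, with a likely range from 800 nM to 3000 nM.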

Compound 4, half-maximal inhibitory concentration: 1000 nM
Compound 4: the middle estimate sits 1.5-fold (0.18 log units) above what was measured; measured number inside the range.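

In this assay, putting (pyridin-2-yl)methyl in place of phenyl on the core of compound 3 gives a 1.6-fold higher number from compound 3 to compound 4 (0.21 log units; within the scatter), so on this core the two compounds cannot be told apart, while on the other core the same change gave a 2.4-fold higher number from compound 2 to compound 1 (0.39 log units; beyond the scatter). Within the data shown here, although only one of these two steps lies beyond the scatter, the steps themselves cannot be distinguished from each other: the same change on two cores in this assay, a 2.4-fold higher number (0.39 log units; beyond the scatter) from compound 2 to compound 1 and a 1.6-fold higher number (0.21 log units; within the scatter) from compound 3 to compound 4, 1.5-fold (0.18 log units) apart, within the scatter of two such steps This shows that the two cores give no measurable sign of handling the change differently, but it does not show that the step is truly the same size on both, and two pairs offer no rule for any further core.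

The change brings in a chain carbon and a ring nitrogen together, so the compounds shown leave open what each contributes alone, which benzyl or pyridin-2-yl in the same place on either core could separate in this assay. On these data alone, it also remains open whether the step would look the same with an amine or a carboxylic acid on the aromatic ring in place of these unsubstituted groups.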